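The source may report more compounds than this note shows. Statements on the series, on what has been measured and on what is new or still open speak of the compounds shown alone.

Measured compounds:
compound 1 `O=c1c(CSC(=S)N2CCCC2)coc2ccccc12`, 2300 nM
compound 2 `Cc1ccc2c(=O)c(CSC(=S)N3CCCC3)coc2c1`, 5900 nM
compound 3 `O=c1c(CSC(=S)N2CCCCC2)coc2cc(Cl)ccc12`, 790 nM

In a functional assay on SW480 cells (Homo sapiens) for antiproliferative activity, read by MTT assay, with a stated time of 72 h (on this read-out higher numbers stand for weaker inhibition and lower numbers for stronger inhibition), compound 3 gives the lowest number of the three; compound 1 gives a higher number and compound 2 a higher number still, both gaps beyond the scatter. Going by the values given here, the only single-change step measured, a 2.6-fold higher number from compound 1 to compound 2 (0.41 log units; beyond the scatter), concerns a methyl on an aromatic carbon and does not touch the ring on the thiocarbonyl carbon. Compound 4 `O=c1c(CSC(=S)N2CCCC2)coc2cc(Cl)ccc12` differs from compound 3 by pyrrolidin-1-yl in place of piperidin-1-yl on a thiocarbonyl carbon. Among the compounds with values here, no measured pair isolates this change; compound 1 and compound 3 differ in two places, so their gap cannot be assigned to it. Compound 4 is therefore expected to show a 1.3-fold higher number from compound 3 to compound 4 (0.10 log units; within the scatter), no change beyond the scatter, with an estimate of 1000 nM in this assay, between 400 nM and 2500 nM.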

Compound 4, half-maximal inhibitory concentration: 7800 nM
Estimate against measurement, compound 4: 7.8-fold (0.89 log units) below, outside the stated range (above it).
By their numbers in this assay, from the lowest: compound 3; then compound 1; then compounds 2 and 4 (each within the scatter of the next).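

In this assay the ring on the thiocarbonyl carbon proves to matter, with the chloro group held constant: pyrrolidin-1-yl in place of piperidin-1-yl gives a 9.9-fold higher number from compound 3 to compound 4 (0.99 log units; beyond the scatter) and is the largest step in the series. With pyrrolidin-1-yl kept, chloro in place of hydrogen gives a 3.4-fold higher number from compound 1 to compound 4 (0.53 log units; beyond the scatter) as a modest loss, while chloro in place of methyl gives a 1.3-fold higher number from compound 2 to compound 4 (0.12 log units; within the scatter) and so does not separate these two groups. Nothing available here explains these steps.

Open, as far as these compounds go, is whether the piperidin-1-yl gain holds without the chloro group. Also open, from the compounds shown here alone, is how morpholin-4-yl or dimethylamino would read on the thiocarbonyl carbon.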